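The source may report more compounds than this note shows. Statements on the series, on what has been measured and on what is new or still open speak of the compounds shown alone.

For the measured compounds named here, in a functional assay on U-87MG ATCC cells for cytotoxicity against U-87 MG (Homo sapiens), read by MTT assay, with a stated time of 72 h (a higher number here means a weaker inhibitor, a lower number a stronger inhibitor), compound 1 `COc1ncc(-c2ccc3nc(NC(=O)NCC(=O)N4CCCCC4)nn3c2)cc1NS(=O)(=O)c1ccc(F)cc1` gives 740 nM and compound 2 `COc1ncc(-c2ccc3nc(NC(=O)N(C)C)nn3c2)cc1NS(=O)(=O)c1ccc(F)cc1` gives 1780 nM as the only pair separated beyond the scatter, with a 2.4-fold higher number from compound 1 to compound 2 (0.38 log units; beyond the scatter) as the step. Compound 3 `COc1ncc(-c2ccc3nc(NC(=O)NCCN4CCCC4)nn3c2)cc1NS(=O)(=O)c1ccc(F)cc1` gives 1120 nM and lies within the scatter of both, with a 1.5-fold higher number from compound 1 to compound 3 (0.18 log units; within the scatter) on one side and a 1.6-fold lower number from compound 2 to compound 3 (0.20 log units; within the scatter) on the other.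

Going by the values given here, compound 4 `COc1ncc(-c2ccc3nc(NC(=O)NCC(=O)N4CCCC4)nn3c2)cc1NS(=O)(=O)c1ccc(F)cc1` is reached from compound 3 through (pyrrolidin-1-yl)carbonyl in place of (pyrrolidin-1-yl)methyl on a saturated chain carbon bound to an amide-type nitrogen as its one change, with (pyrrolidin-1-yl)carbonyl in place of (pyrrolidin-1-yl)methyl on a saturated chain carbon bound to an amide-type nitrogen.

The closest measured evidence is the step at that same place, a 1.5-fold higher number from compound 1 to compound 3 (0.18 log units; within the scatter) as measured, read backwards, with (piperidin-1-yl)carbonyl on the compound 1 side. It suggests at most a small move toward a lower number. Among the compounds with values here, no measured step isolates the pyrrolidine carbonyl group itself.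

The estimated step is a 1.4-fold lower number from compound 3 to compound 4 (0.14 log units; within the scatter) and no shift beyond the scatter is expected. Compound 4 is expected near 820 nM with an estimated range from 420 nM to 1600 nM in this series.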

Compound 4, half-maximal inhibitory concentration: 1000 nM
For compound 4 the middle estimate is 1.2-fold (0.09 log units) below the measured one; the range from low to high includes it.
By their numbers in this assay, from the lowest: compounds 1, 4, 3 and 2 (each within the scatter of the next, the first and the last beyond it).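

In this assay, for the compounds shown here, the first reading of (pyrrolidin-1-yl)carbonyl against (pyrrolidin-1-yl)methyl with the ring kept the same on a saturated chain carbon bound to an amide-type nitrogen stays inside the scatter (a 1.1-fold lower number from compound 3 to compound 4 (0.05 log units; within the scatter)), so this place tolerates the carbonyl without a resolved shift. Pyrrolidin-1-yl in place of piperidin-1-yl on a carbonyl carbon is also unresolved (a 1.4-fold higher number from compound 1 to compound 4 (0.13 log units; within the scatter)), and (((pyrrolidin-1-yl)carbonyl)methyl)amino in place of dimethylamino on a carbonyl carbon (a 1.8-fold lower number from compound 2 to compound 4 (0.25 log units; within the scatter)) remains within the scatter, leaving compound 1 as the only compound separated from compound 2. No measurement is available that accounts for these small steps.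

Still open, from the compounds shown here alone, is whether a morpholin-4-yl ring on the carbonyl, a carboxylic acid or a longer chain at this place would give a step beyond the scatter. The readings also leave open whether this order holds in any other cell line.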